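The source may report more compounds than this note shows. Statements on the series, on what has been measured and on what is new or still open speak of the compounds shown alone.

Of the compounds shown here, three have so far been measured in a functional assay on CHO cells for antagonist activity at transient receptor potential cation channel subfamily V member 1 (Homo sapiens), read by FLIPR; a lower number here means a stronger inhibitor, a higher number a weaker inhibitor. Compound 1 `O=C(Nc1ccc(-c2ncccc2C(F)(F)F)cc1)c1ccc(C(F)(F)F)cc1` gives 24 nM in this assay, compound 2 `CC(C)(C)c1ccc(-c2nc3cc(-c4ncccc4C(F)(F)F)ccc3[nH]2)cc1` gives 224 nM, and compound 3 `O=c1c2cc(-c3ncccc3C(F)(F)F)ccc2[nH]n1-c1ccc(C(F)(F)F)cc1` gives 370 nM. Compound 3 thus carries the highest of the three numbers. Its value and that of compound 2 lie within the usual scatter of each other, so nothing separates them, while the number for compound 1 is far lower, a gap well beyond the scatter, so compound 1 is the stronger inhibitor of that pair. All three carry a 3-(trifluoromethyl)pyridin-2-yl group.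

Compound 4 `O=c1c2ccccc2[nH]n1-c1ccc(C(F)(F)F)cc1` has not been measured. It differs from compound 3 in one place: hydrogen in place of 3-(trifluoromethyl)pyridin-2-yl on an aromatic carbon. Within the data shown here, no pair of measured compounds differs by this change alone, so its size cannot be read from the data. Removal of this group is expected to weaken inhibition markedly, because compound 1 at 24 nM and compound 3 at 370 nM both carry the group, as does every measured compound. The expected step of a 14-fold higher number from compound 3 to compound 4 (1.13 log units; beyond the scatter) is therefore a large loss. Compound 4 is estimated at 5000 nM, with a range from 1500 nM to 20000 nM.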

Compound 4, half-maximal inhibitory concentration: 340 nM
Estimate against measurement, compound 4: 15-fold (1.17 log units) above; measured number outside the range, below it.
By their numbers in this assay, from the lowest: compound 1; then compounds 2, 4 and 3 (each within the scatter of the next).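

In this assay the change gives a 1.1-fold lower number from compound 3 to compound 4 (0.04 log units; within the scatter), so on this core the two compounds cannot be told apart. Every earlier compound carried the 3-(trifluoromethyl)pyridin-2-yl group, which left its contribution unknown; this pair shows that, on this aromatic carbon of the core shared by compound 3 and compound 4, a group of 10 heavy atoms can give way to hydrogen with no measurable loss of inhibition. Nothing shown explains this result.

Going by these compounds, it remains open whether a different group on the same carbon, such as a methyl group, an amine or a carboxylic acid, would move the number beyond the scatter. No compound shown differs from compound 1 or compound 2 in one place, so whether either of them would also tolerate losing the group cannot be read.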